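The source may hold more compounds than are shown below. What is called first, only, known or untested is meant among the compounds shown, and "the series" means these compounds.

In a functional assay on A549 cells (Homo sapiens) for cytotoxicity, read by MTT assay, with a stated time of 72 h (a higher number here means a weaker inhibitor, a lower number a stronger inhibitor), compound 3 `CN(C)Cc1ccc2nc(NC(=O)N/N=C/c3c[nH]c4ccccc34)sc2c1` gives 3300 nM. It stands level with compound 1 `CCN(CC)Cc1ccc2nc(NC(=O)N/N=C/c3c[nH]c4ccccc34)sc2c1`, which gives 3300 nM; together these are the highest of the three numbers. Compound 2 `CN(C)Cc1ccc2nc(NC(=O)N/N=C/c3cn(Cc4ccccc4)c4ccccc34)sc2c1` gives 2900 nM, and the step of a 1.1-fold higher number from compound 2 to compound 3 (0.06 log units; within the scatter) lies within the scatter, as does the step of no change at the digits printed from compound 1 to compound 3 (within the scatter). Compound 4 `CN(C)Cc1ccc2nc(NC(=O)N/N=C/c3cn(Cc4ccc(C(C)(C)C)cc4)c4ccccc34)sc2c1` has not been measured. It differs from compound 3 in one place: 4-(tert-butyl)benzyl in place of hydrogen on an aromatic nitrogen. Going by the values given here, the one measured step that bears on this exchange is a 1.1-fold higher number from compound 2 to compound 3 (0.06 log units; within the scatter), in which hydrogen replaces benzyl on an aromatic nitrogen, and it moved the number only within the scatter. Among the compounds with values here, no measured compound addresses the tert-butyl part of the entering group. On this basis no step beyond the scatter is expected in this assay, and the step of a 1.1-fold lower number from compound 3 to compound 4 (0.04 log units; within the scatter) is the estimate. Compound 4 is therefore expected to give about 3000 nM, with a range from 1500 nM to 6500 nM.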

Compound 4, half-maximal inhibitory concentration: 1850 nM
The estimate for compound 4 lay 1.6-fold (0.21 log units) above the measured number, and the stated range covers the measured number.
By their numbers in this assay, from the lowest: compounds 4, 2, 1 and 3 (each within the scatter of the next).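

In this assay, placing 4-(tert-butyl)benzyl on the aromatic nitrogen gives a 1.8-fold lower number from compound 3 to compound 4 (0.25 log units; within the scatter), so a group of 11 carbon atoms at this position leaves the number within the scatter, as benzyl did before it. Going by these compounds alone, the tert-butyl part, which no earlier compound addressed, gives a 1.6-fold lower number from compound 2 to compound 4 (0.20 log units; within the scatter), and this exchange on an aromatic carbon of the benzyl group also stays within the scatter. Nothing at hand gives a reason for these numbers.

The compounds shown leave open whether a carboxylic acid or an amine on the benzyl group, or a longer chain such as n-octyl on the aromatic nitrogen, would move the number beyond the scatter. Also open, as far as these compounds go, is whether a morpholine in place of the dimethylamino group would do so.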